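The source may report more compounds than this note shows. Statements on the series, on what has been measured and on what is new or still open speak of the compounds shown alone.

Compound 1 `Oc1ccc(O)c(-c2cc(-c3ccc(Cl)cc3)nn2-c2ccccc2)c1` gives 6850 nM in a functional assay on cells (Cancer cell lines, Homo sapiens) for cytotoxicity, read by sulforhodamine B assay, with a stated time of 48 h; on this read-out higher numbers stand for weaker inhibition of growth and lower numbers for stronger inhibition of growth. Compound 2 `NS(=O)(=O)c1ccc(-n2nc(-c3ccc(Cl)cc3)cc2-c2cc(O)ccc2O)cc1` gives 13000 nM in this assay and stands alongside compound 1 on the numbers shown, as the step of a 1.9-fold higher number from compound 1 to compound 2 (0.28 log units; within the scatter) lies within the scatter. Compound 3 `CC(=O)NS(=O)(=O)c1ccc(-n2nc(-c3ccc(Cl)cc3)cc2-c2cc(O)ccc2O)cc1` differs from compound 2 by acetyl in place of hydrogen on a sulfonamide nitrogen. Within the data shown here, no measured step alters the sulfonamide nitrogen, and the single step available, a 1.9-fold higher number from compound 1 to compound 2 (0.28 log units; within the scatter), stays within the scatter, so no movement beyond the scatter is expected in this assay. Compound 3 is therefore expected to give 15000 nM, between 6000 nM and 35000 nM. The step is thus expected to read a 1.2-fold higher number from compound 2 to compound 3 (0.06 log units; within the scatter).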

Compound 3, concentration for 50% growth inhibition: 36200 nM
Estimate against measurement, compound 3: 2.4-fold (0.38 log units) below; measured number outside the range, above it.
By their numbers in this assay, from the lowest: compounds 1 and 2 (each within the scatter of the next); then compound 3.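

In this assay, acetyl in place of hydrogen on a sulfonamide nitrogen moves the number beyond the scatter, a 2.8-fold higher number from compound 2 to compound 3 (0.44 log units; beyond the scatter), towards weaker inhibition of growth. Acetylsulfamoyl in place of hydrogen on an aromatic carbon likewise reads a 5.3-fold higher number from compound 1 to compound 3 (0.72 log units; beyond the scatter), whereas sulfamoyl alone stayed within the scatter of compound 1. No measurement shown here accounts for this change.

The compounds shown leave open whether a longer chain, such as propionyl, or a benzoyl on the sulfonamide nitrogen would read like acetyl. They also leave open how a carboxylic acid would read in place of the sulfamoyl group.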